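Swapping the pyridine for a methylphenyl on the amide

The compounds below may be only part of what the source reports. "The series", "measured", "known", "first", "only" and "open" are said of these compounds alone.

Measured so far:
compound 1 `O=C(NCc1ccc(CNS(=O)(=O)c2ccccc2)cc1)c1c(Cl)cc(Cl)cc1Cl`: 10 nM
compound 2 `O=C(NCc1ccc(CNS(=O)(=O)c2ccccc2)cc1)c1cccc(Cl)c1`: 1000 nM
compound 3 `O=C(NCc1ccc(CNS(=O)(=O)c2ccccc2)cc1)c1cccnc1`: 10 nM

In an assay on MDA-MB-231 cells for binding affinity to C-X-C chemokine receptor type 4 (Homo sapiens), read by immunofluorescence and microscopy, with stated times of 10 min and 30 min (a lower number here means that less compound is needed, a higher number that more compound is needed for the effect), compound 3 gives 10 nM, level with compound 1 and together with it the lowest of the three numbers; compound 2 lies far above, as a 100-fold lower number from compound 2 to compound 3 (2.00 log units; beyond the scatter) shows. Compound 4 `Cc1ccc(C(=O)NCc2ccc(CNS(=O)(=O)c3ccccc3)cc2)cc1` differs from compound 3 only by 4-methylphenyl in place of pyridin-3-yl on a carbonyl carbon. Within the data shown here, two steps bear on this: no change at the digits printed from compound 1 to compound 3 (within the scatter) was flat, whereas a 100-fold lower number from compound 2 to compound 3 (2.00 log units; beyond the scatter) was large. A single ring of carbon only with one substituent resembles compound 2 more than compound 1, so a rise beyond the scatter is expected, though smaller than that step. Compound 4 is estimated at 200 nM, within 20 nM to 2000 nM, which is an expected step of a 20-fold higher number from compound 3 to compound 4 (1.30 log units; beyond the scatter).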

Compound 4, effective concentration (reported as EC, without a stated level of effect): 100 nM
The estimate for compound 4 lay 2.0-fold (0.30 log units) above the measured number, within the range that was stated.
By their numbers in this assay, from the lowest: compounds 1 and 3 (each within the scatter of the next); then compound 4; then compound 2.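

In this assay, placing 4-methylphenyl on the carbonyl carbon gives a 10-fold higher number from compound 3 to compound 4 (1.00 log units; beyond the scatter) and also a 10-fold higher number from compound 1 to compound 4 (1.00 log units; beyond the scatter) as the two comparisons with the lowest numbers. Yet it also gives a 10-fold lower number from compound 2 to compound 4 (1.00 log units; beyond the scatter) against 3-chlorophenyl, so two rings of carbon only, each with one substituent, now differ beyond the scatter at this position. Nothing available here accounts for these steps.

As far as these compounds go, whether the identity of the substituent or its place on the ring sets that gap remains open. So does how 3-methylphenyl, 4-chlorophenyl or an aminophenyl group would read here.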